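The source may report more compounds than this note shows. Statements on the series, on what has been measured and on what is new or still open speak of the compounds shown alone.

Measured so far in an ADME assay for permeability, using PAMPA, at pH 4; a lower number here means that the compound crosses the layer more slowly, a higher number that the compound crosses the layer faster:
- compound 1 `Cc1[nH]c2ccccc2c(=O)c1C1CCCCC1`: 260 10^-6 cm/s
- compound 2 `Cc1[nH]c2ccccc2c(=O)c1Br`: 8.19 10^-6 cm/s
- compound 3 `CCCCC#Cc1c(C)[nH]c2ccc(OC)cc2c1=O`: 1020 10^-6 cm/s

Compound 3, at 1020 10^-6 cm/s, holds the highest number of the three, and its gaps to compound 1 and compound 2 both lie beyond the scatter.

The next compound is compound 4 `CCCCC#Cc1c(C)[nH]c2ccccc2c1=O`, with hydrogen in place of methoxy on an aromatic carbon. The rest of the structure stays as in compound 3.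

For the measured compounds named here, only one measured step is available, a 32-fold lower number from compound 1 to compound 2 (1.50 log units; beyond the scatter). It is large, but it is a different change, bromo in place of cyclohexyl on an aromatic carbon. It shows that this assay can move widely within this series, but says nothing direct about methoxy. Going by the values given here, no measured pair isolates the loss of methoxy, so no step beyond the scatter is expected, in either direction, and the range is kept wide.

The estimate means a 1.3-fold lower number from compound 3 to compound 4 (0.11 log units; within the scatter), an expected change within the scatter. Compound 4 is expected at 800 10^-6 cm/s, with an estimated range of 300 10^-6 cm/s to 1800 10^-6 cm/s.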

Compound 4, apparent permeability: 500 10^-6 cm/s
Compound 4: the middle estimate sits 1.6-fold (0.20 log units) above what was measured; the measured number falls inside the stated range.
By their numbers in this assay, from the lowest: compound 2; then compounds 1 and 4 (each within the scatter of the next); then compound 3.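

In this assay, the carbon carrying methoxy gives its first isolated reading: with hex-1-yn-1-yl held fixed, hydrogen in place of methoxy gives a 2.0-fold lower number from compound 3 to compound 4 (0.31 log units; beyond the scatter), so this position has a modest effect on the read-out, far smaller than the change at the other site. At that other site, hex-1-yn-1-yl in place of bromo gives a 61-fold higher number from compound 2 to compound 4 (1.79 log units; beyond the scatter), whereas hex-1-yn-1-yl in place of cyclohexyl gives a 1.9-fold higher number from compound 1 to compound 4 (0.28 log units; within the scatter) and leaves those two groups unseparated. Nothing measured here accounts for these steps.

For the compounds shown here, whether the methoxy step carries over to compounds with cyclohexyl or bromo remains open, since only one pair isolates it. Also open, as far as these compounds go, is how an amine or a carboxylic acid on the methoxy-bearing carbon would read, or a longer chain in place of hex-1-yn-1-yl.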